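A few compounds are considered here, and "the series" means these few. Any claim that something is new, unique, unknown or untested is made for them only; others in the source may bear on it.

Compound 1 `N#Cc1cc(F)cc(C#Cc2csc(Br)n2)c1` is the stronger of the two measured compounds in an assay on brain for displacement of a labelled ligand from metabotropic glutamate receptor 5 (Rattus norvegicus); a lower number here means a stronger inhibitor, a higher number a weaker inhibitor: compound 1 gives 0.95 nM, and compound 2 `Fc1nc(C#Cc2ccccc2)cs1` gives 122 nM, a gap that lies far beyond the scatter of the method. Within the data shown here, only two measured values exist, and no step between compounds that differ in a single place has been recorded, so the comparison between compound 1 and compound 2 says nothing about any one group on its own.

Compound 3 `N#Cc1cc(F)cc(C#Cc2csc(N)n2)c1` has not yet been measured in this assay. It differs from compound 1 in one place: amino in place of bromo on an aromatic carbon. The shared core of compound 1 is otherwise kept, including the nitrile and the fluorine on the other ring.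

Among the measured compounds shown here, with no single-point step among the measured compounds to lean on, the account expects a moderate loss, with the step from compound 1 to compound 3 estimated at an 8.4-fold higher number from compound 1 to compound 3 (0.93 log units; beyond the scatter), a change in the direction of a weaker inhibitor that goes beyond the scatter. Compound 3 is accordingly expected to give about 8 nM in this assay, within a range of 2 nM to 40 nM.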

Compound 3, inhibition constant: 0.25 nM
Compound 3: middle estimate off by 32-fold (1.51 log units), on the high side, and the stated range ends above it.
By their numbers in this assay, from the lowest: compound 3; then compound 1; then compound 2.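

Putting amino in place of bromo on the aromatic carbon next to the ring nitrogen and next to the ring sulfur gives a 3.8-fold lower number from compound 1 to compound 3 (0.58 log units; beyond the scatter) in this assay, a modest step toward a stronger inhibitor that lies beyond the scatter. Among these compounds, this is the first comparison here between compounds that differ in one place, and it shows that bromo is not required at this position: a nitrogen-bearing group with a hydrogen-bond donor and a hydrogen-bond acceptor can stand there while the number still falls. Nothing measured here bears on why this exchange gives a lower number, so the step stands as an observation only.

The compounds shown leave open whether the step belongs to amino in particular, since a methylamino, a dimethylamino, an acetamido or a hydroxyl group at the same position, or plain hydrogen, would each test that in a different way. They also leave open whether the same exchange gives a step of similar size on a compound without the nitrile and the fluorine on the other ring.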